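Chloro to Fluoro on Two Related Diaminoquinazoline Nitriles

The source may report more compounds than this note shows. Statements on the series, on what has been measured and on what is new or still open speak of the compounds shown alone.

Measured compounds:
Compound 1 `N#Cc1c(NCc2ccccc2)c(Cl)c2nc(N)nc(N)c2c1F` gives 1.4 ug/mL.
Compound 2 `N#Cc1c(NCc2ccccc2)c(F)c2nc(N)nc(N)c2c1F` gives 12.9 ug/mL.
Compound 3 `CCCCNc1c(C#N)c(NCCCC)c2c(N)nc(N)nc2c1Cl` gives 2.5 ug/mL.

All three were tested in a functional assay on A-431 cells (Homo sapiens) for cytotoxicity, read by MTT assay; on this read-out lower numbers stand for stronger inhibition and higher numbers for weaker inhibition. Compound 1 and compound 2 differ only in one place: fluoro in place of chloro on an aromatic carbon. That change gave a 9.2-fold higher number from compound 1 to compound 2 (0.96 log units; beyond the scatter). Compound 3 carries butylamino groups instead of the benzylamino group of compound 1; the difference between the two cores is not broken down here. Compound 3 and compound 1 give numbers within the scatter of each other, while compound 2 stands well apart from both.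

Compound 4 `CCCCNc1c(C#N)c(NCCCC)c2c(N)nc(N)nc2c1F` has not been measured. It relates to compound 3 as compound 2 relates to compound 1: fluoro in place of chloro on an aromatic carbon. The surroundings are not identical, since the carbon is ortho to a butylamino group and para to a butylamino group rather than ortho to a benzylamino group and para to a fluoro group, so this is the same kind of change, not the same. Because the earlier step was a 9.2-fold higher number from compound 1 to compound 2 (0.96 log units; beyond the scatter), compound 4 is expected to give a weaker number than compound 3, with an expected step of a 6.0-fold higher number from compound 3 to compound 4 (0.78 log units; beyond the scatter). The estimate for compound 4 is 15 ug/mL, spanning 5 ug/mL to 45 ug/mL.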

Compound 4, half-maximal inhibitory concentration: 1 ug/mL
Compound 4: the middle estimate sits 15-fold (1.18 log units) above what was measured, and the stated range ends above it.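

In this assay, fluoro in place of chloro on an aromatic carbon gave a 2.5-fold lower number from compound 3 to compound 4 (0.40 log units; beyond the scatter), so the change did not act the same way on the core of compound 3 as on the core of compound 1. The two steps run in opposite directions, and the gap between them is larger than repeated measurements would explain: the same change on two cores in this assay, a 9.2-fold higher number (0.96 log units; beyond the scatter) from compound 1 to compound 2 and a 2.5-fold lower number (0.40 log units; beyond the scatter) from compound 3 to compound 4, 23-fold (1.36 log units) apart, beyond the scatter of two such steps. Among the compounds shown, the outcome of this change on one core therefore did not predict its outcome on the other, but two pairs cannot show which difference between the cores matters, and they establish no rule for the wider series.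

The compounds shown leave open whether the opposite outcome follows the butylamino groups or the other substituents that separate the two cores. They also leave open how the same change would behave with a dimethylamino group or a longer chain such as hexylamino in place of butylamino, and how bromo would compare with chloro and fluoro on that carbon.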